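The source may report more compounds than this note shows. Statements on the series, on what has been measured and on what is new or still open speak of the compounds shown alone.

Measured so far:
compound 1, `Nc1cccc2c(-c3cccc(NC(=O)c4ccc(Cl)c(C(F)(F)F)c4)c3)ccnc12`, gives 2800 nM in a functional assay on UACC-257 cells (Homo sapiens) for antiproliferative activity, read by sulforhodamine B assay, with a stated time of 48 h; a higher number here means a weaker inhibitor, a lower number a stronger inhibitor
compound 2, `CC(=O)Nc1cccc2c(-c3cccc(NC(=O)c4ccc(Cl)c(C(F)(F)F)c4)c3)ccnc12`, gives 2700 nM
compound 3, `Nc1cccc2c(-c3cccc(NC(=O)Nc4cc(C(F)(F)F)cc(C(F)(F)F)c4)c3)ccnc12`, gives 1000 nM

Compound 2 differs from compound 1 by acetyl in place of hydrogen on a nitrogen on an aromatic ring, and that change gave the step of a 1.0-fold lower number from compound 1 to compound 2 (0.02 log units; within the scatter), so the number hardly moved. Compound 3 has a different core; how the two cores differ is not broken down here. Compound 3 gives the lowest number of the three measured compounds, with both of the others beyond the usual scatter from it.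

Compound 4, `CC(=O)Nc1cccc2c(-c3cccc(NC(=O)Nc4cc(C(F)(F)F)cc(C(F)(F)F)c4)c3)ccnc12`, stands to compound 3 exactly as compound 2 stands to compound 1: acetyl in place of hydrogen on a nitrogen on an aromatic ring, the same change at the same kind of place. Because the earlier step of a 1.0-fold lower number from compound 1 to compound 2 (0.02 log units; within the scatter) stayed flat, the step from compound 3 to compound 4 is also expected to be small, about no change at the digits printed from compound 3 to compound 4 (within the scatter). Compound 4 is therefore estimated to give about 1000 nM in this assay, most likely between 500 nM and 2200 nM.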

Compound 4, half-maximal inhibitory concentration: 14100 nM
Compound 4: the middle estimate sits 14-fold (1.15 log units) below what was measured; measured number outside the range, above it.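

In this assay, acetyl in place of hydrogen on a nitrogen on an aromatic ring gave a 14-fold higher number from compound 3 to compound 4 (1.15 log units; beyond the scatter), so this change does not act the same way on the two cores: the same change on two cores in this assay, a 1.0-fold lower number (0.02 log units; within the scatter) from compound 1 to compound 2 and a 14-fold higher number (1.15 log units; beyond the scatter) from compound 3 to compound 4, 15-fold (1.17 log units) apart, beyond the scatter of two such steps

A flat step on one core is therefore a poor guide to the same step on the other in this series. The result does not show which part of the cores makes the difference, nor why, and two steps give no general rule.

From the compounds shown here alone, it remains open how either core would respond to another group on that nitrogen, such as a methyl group or a propanoyl group. Going by these compounds, it is also open whether an acetyl group elsewhere on the compounds would give a similar step.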